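A Trifluoromethyl Step on a Sparingly Soluble Core

A few compounds are considered here, and "the series" means these few. Any claim that something is new, unique, unknown or untested is made for them only; others in the source may bear on it.

Solubility here comes from a physicochemical assay for solubility, read by HPLC, using the shake flask method, measured as kinetic solubility, with a stated time of 2 h, at pH 7.4; a lower number here means a less soluble compound, a higher number a more soluble compound. Compound 3, with structure `Cc1cc(NCc2ccccn2)n2ncc(-c3ccc(N(C)C)cc3)c2n1`, gives < 5000 nM in this assay, which is a limit of the assay rather than a number. Two companions share the same core and the same pyridylmethylamine arm and differ only in the group on the pendant aromatic ring. Compound 1, `Cc1cc(NCc2ccccn2)n2ncc(-c3ccc(F)cc3)c2n1`, gives < 5000 nM, again a limit. Compound 2, `COc1ccc(-c2cnn3c(NCc4ccccn4)cc(C)nc23)cc1`, gives < 5000 nM, also a limit. Because of the limit of < 5000 nM in this assay, at which 3 of the 3 values shown sit, the steps between these three cannot be sized: a step that the two limits leave unreadable from compound 1 to compound 2, a step that the two limits leave unreadable from compound 1 to compound 3 and a step that the two limits leave unreadable from compound 2 to compound 3. The unmeasured compound 4 has structure `Cc1cc(NCc2ccccn2)n2ncc(-c3ccc(C(F)(F)F)cc3)c2n1`. Its change from compound 3 is trifluoromethyl in place of dimethylamino on an aromatic carbon. Within the data shown here, none of the measured steps is readable, so nothing points to a rise or fall beyond the scatter; the only firm information is that every fluoro, methoxy or dimethylamino variant sits at the limit. The expected step is therefore a step that the limit leaves unreadable from compound 3 to compound 4, a step expected to keep compound 4 near its neighbours. Compound 4 is estimated at 2000 nM, within an expected range from 300 nM to 6000 nM, and most likely reported again as a limit.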

Compound 4, solubility: < 5000 nM
Compound 4: no number, only a limit; the forecaster's own chance of this, stated with the estimate: 80%; the middle value is on the limit's open side.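

No step from compound 1, compound 2 or compound 3 to compound 4 can be read, because all of them stop at the same assay limit rather than giving a number: the limit of < 5000 nM in this assay, at which 4 of the 4 values shown sit.

From the compounds shown here alone, how far the solubility of these four compounds lies under that limit, and whether the group on the pendant aromatic ring changes it at all, stays open.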